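Chain extension on the dimethylamino member of the series

The source may report more compounds than this note shows. Statements on the series, on what has been measured and on what is new or still open speak of the compounds shown alone.

In a functional assay on HCT-116 cells (Homo sapiens) for antiproliferative activity, read by MTT assay, with a stated time of 48 h (a higher number here means a weaker inhibitor, a lower number a stronger inhibitor), compound 1 `CCCCCCCC(CCO)n1cnc2c(OC)ncnc21` gives 15300 nM and compound 2 `CCCCCCCC(CCO)n1cnc2c(NC)ncnc21` gives 12500 nM. Compound 3 `CCCCCCCC(CCO)n1cnc2c(N(C)C)ncnc21` gives > 50000 nM, which is a limit of the assay and not a number. Compound 4 `CCCCCCCCC(CCO)n1cnc2c(N(C)C)ncnc21` carries methyl in place of hydrogen on a saturated chain carbon, eight bonds along the chain from an aromatic nitrogen. The measured steps, a 1.2-fold lower number from compound 1 to compound 2 (0.09 log units; within the scatter), an at least 3.2-fold higher number from compound 1 to compound 3 (0.51 log units; beyond the scatter) and an at least 4.0-fold higher number from compound 2 to compound 3 (0.60 log units; beyond the scatter), all change the group on the aromatic carbon and leave the chain unchanged, so none gives a direct measure for this change. In this assay, no step beyond the scatter is expected, and the expected step is an at least 1.2-fold lower number from compound 3 to compound 4 (0.09 log units; that floor lies within the scatter). Compound 4 is estimated at 40000 nM, with an expected range of 15000 nM to 100000 nM.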

Compound 4, half-maximal inhibitory concentration: 19800 nM
Beside the measured number, compound 4's estimate is 2.0-fold (0.31 log units) above it; measured number inside the range.
By their numbers in this assay, from the lowest: compounds 2, 1 and 4 (each within the scatter of the next). At a limit, above all of these: compound 3.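

In this assay, methyl in place of hydrogen on a saturated chain carbon, eight bonds along the chain from an aromatic nitrogen, gives an at least 2.5-fold lower number from compound 3 to compound 4 (0.40 log units; beyond the scatter). Among these compounds, the earlier steps changed only the group on the aromatic carbon, so this is the first sign that the chain also moves the number. Compound 3 stands at a limit and not a number, so the step is known only as a floor: the limit of > 50000 nM in this assay, at which 1 of the 4 values shown sits.

As far as these compounds go, whether a longer chain lowers the number further remains open. So does whether the same extension acts alike with methoxy or methylamino on the aromatic carbon.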